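The compounds below may be only part of what the source reports. "The series", "measured", "known", "first", "only" and "open" are said of these compounds alone.

In a functional assay on MV4-11 cells (Homo sapiens) for antiproliferative activity, read by resazurin assay, with a stated time of 72 h (on this read-out lower numbers stand for stronger inhibition and higher numbers for weaker inhibition), the series is read with compound 3, whose structure is `COc1cc(-c2c(C#N)c(-c3ccccc3)nc3c2c(-c2ccccc2)nn3-c2ccccc2)ccc1O`. Compound 3 gives only a limit of the assay, > 50000 nM, and so sits at the limit of > 50000 nM in this assay, at which 1 of the 3 values shown sits, rather than at a number. The two compounds that give numbers are compound 1, with the structure `N#Cc1c(-c2ccco2)nc2c(c(-c3ccccc3)nn2-c2ccccc2)c1-c1ccc(O)cc1`, which gives 13800 nM, and compound 2, with the structure `Cc1ccc(-c2nc3c(c(-c4ccccc4)nn3-c3ccccc3)c(-c3ccc(O)cc3)c2C#N)cc1`, which gives 3300 nM. Within the data shown here, the one measured step, a 4.2-fold lower number from compound 1 to compound 2 (0.62 log units; beyond the scatter), concerns a different part of the shared core and so does not bear directly on the change at hand. The unmeasured compound 4 has the structure `N#Cc1c(-c2ccccc2)nc2c(c(-c3ccccc3)nn2-c2ccccc2)c1-c1ccc(O)cc1` and differs from compound 3 by hydrogen in place of methoxy on an aromatic carbon. With compound 3 known only as a limit, the size of the step cannot be drawn from a measured pair; a move back to a number in the range of compound 1 and compound 2 is expected, so compound 4 is estimated at 8000 nM, between 2500 nM and 30000 nM, which is expected to mean an at least 6.2-fold lower number from compound 3 to compound 4 (0.79 log units; beyond the scatter).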

Compound 4, half-maximal inhibitory concentration: 26100 nM
Beside the measured number, compound 4's estimate is 3.3-fold (0.51 log units) below it; the range from low to high includes it.
By their numbers in this assay, from the lowest: compound 2; then compounds 1 and 4 (each within the scatter of the next). At a limit, above all of these: compound 3.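

Compound 3 is held at a limit rather than a number: the limit of > 50000 nM in this assay, at which 1 of the 4 values shown sits. Going from 4-hydroxy-3-methoxyphenyl to 4-hydroxyphenyl in this assay can therefore be read only as a floor, an at least 1.9-fold lower number from compound 3 to compound 4 (0.28 log units; that floor lies within the scatter), so the methoxy may matter a great deal or hardly at all. Compound 4 also gives the other aromatic carbon a plain phenyl for comparison: a 1.9-fold higher number from compound 1 to compound 4 (0.28 log units; within the scatter), whereas a 7.9-fold higher number from compound 2 to compound 4 (0.90 log units; beyond the scatter), so within these three compounds only the 4-methylphenyl group stands apart.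

As far as these compounds go, how far compound 3 truly lies from compound 4 remains open. So does what an ethoxy group, a fluorine atom or an amine would do in the methoxy's place, ortho to the hydroxy group.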